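Working notes: from 4-fluorophenyl to 4-methylphenyl

The source may hold more compounds than are shown below. What is called first, only, known or untested is meant among the compounds shown, and "the series" means these compounds.

Measured so far in a functional assay on FM3A cells (Mus musculus) for antiproliferative activity (on this read-out lower numbers stand for stronger inhibition and higher numbers for weaker inhibition), are two compounds
compound 1 `COc1cc(C(=O)c2sc(-c3ccncc3)cc2N)cc(OC)c1OC` gives 150 nM
compound 2 `COc1cc(C(=O)c2sc(-c3ccc(F)cc3)cc2N)cc(OC)c1OC` gives 16 nM

Compound 2 at 16 nM holds the lower of the two numbers. Compound 3 `COc1cc(C(=O)c2sc(-c3ccc(C)cc3)cc2N)cc(OC)c1OC` departs from it thus: methyl in place of fluoro on an aromatic carbon with methyl in place of fluoro on an aromatic carbon. For the measured compounds named here, the one measured step touching this group is a 9.4-fold lower number from compound 1 to compound 2 (0.97 log units; beyond the scatter) and it exchanges a whole ring, 4-fluorophenyl in place of pyridin-4-yl. No exchange of fluoro for methyl has been measured, and the data fix no direction. A change within the scatter is therefore expected in this assay with the expected step being a 1.1-fold lower number from compound 2 to compound 3 (0.03 log units; within the scatter) in size. The estimate for compound 3 is 15 nM with an estimated range of 5 nM to 50 nM as its bounds.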

Compound 3, half-maximal inhibitory concentration: 16 nM
Compound 3: middle estimate off by 1.1-fold (0.03 log units), on the low side, and the stated range covers the measured number.
By their numbers in this assay, from the lowest: compounds 2 and 3 (each within the scatter of the next); then compound 1.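

In this assay the exchange of fluoro for methyl on this aromatic carbon, para to a large group, gives no change at the digits printed from compound 2 to compound 3 (within the scatter), so these two substituents are not told apart on this read-out. The ring exchange now reads the same with a second substituent: a 9.4-fold lower number from compound 1 to compound 3 (0.97 log units; beyond the scatter), matching a 9.4-fold lower number from compound 1 to compound 2 (0.97 log units; beyond the scatter). The data offer no explanation for either result.

Open, on these data alone, is whether a group such as an amine, a carboxylic acid or a longer chain at this carbon would hold, or move beyond the scatter, the number of compound 3 16 nM.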